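The compounds below may be only part of what the source reports. "The series", "measured", "known", "first", "only" and "open" are said of these compounds alone.

Measured in a functional assay on HepG2 cells (Homo sapiens) for antiproliferative activity, read by MTT assay, with a stated time of 48 h; a higher number here means a weaker inhibitor, a lower number a stronger inhibitor:
- compound 1 `COc1ccccc1NC(=O)Nc1cccc(CNc2nccnc2Cl)c1`: 13700 nM
- compound 2 `O=C(Nc1cccc(Cl)c1)Nc1cccc(CNc2nccnc2Cl)c1`: 9140 nM
- compound 3 `CCc1ccccc1NC(=O)Nc1cccc(CNc2nccnc2Cl)c1`: 7860 nM

Compound 3 is not separated from the other two measured compounds. The data show a 1.2-fold lower number from compound 2 to compound 3 (0.07 log units; within the scatter) and a 1.7-fold lower number from compound 1 to compound 3 (0.24 log units; within the scatter), both within the scatter.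

The next compound is compound 4 `Cc1ccc(NC(=O)Nc2cccc(CNc3nccnc3Cl)c2)cc1`, with 4-methylphenyl in place of 2-ethylphenyl on an amide-type nitrogen. In words, this places 4-methylphenyl in place of 2-ethylphenyl on an amide-type nitrogen. Going by the values given here, no measured compound carries this group, so the evidence is indirect.

The closest guides are the other exchanges of the group on that nitrogen. These are a 1.5-fold lower number from compound 1 to compound 2 (0.18 log units; within the scatter) and a 1.2-fold lower number from compound 2 to compound 3 (0.07 log units; within the scatter), and both stay within the scatter. Among the compounds with values here, the series so far is only three compounds, and it offers no basis for a large move in this assay. No step beyond the scatter is therefore expected, and any direction is tentative.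

The expected change is a 1.1-fold higher number from compound 3 to compound 4 (0.06 log units; within the scatter), which would stay within the scatter.

For compound 4 the estimated value is 9000 nM, with an expected range of 4000 nM to 20000 nM.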

Compound 4, half-maximal inhibitory concentration: 11500 nM
Beside the measured number, compound 4's estimate is 1.3-fold (0.11 log units) below it, within the range that was stated.
By their numbers in this assay, from the lowest: compounds 3, 2, 4 and 1 (each within the scatter of the next).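

In this assay, the exchanges on the amide-type nitrogen now include 4-methylphenyl, and all three steps to it stay within the scatter: a 1.5-fold higher number from compound 3 to compound 4 (0.17 log units; within the scatter), a 1.3-fold higher number from compound 2 to compound 4 (0.10 log units; within the scatter) and a 1.2-fold lower number from compound 1 to compound 4 (0.08 log units; within the scatter). The four groups on this nitrogen (2-methoxyphenyl, 3-chlorophenyl, 2-ethylphenyl and 4-methylphenyl) are therefore not separated from one another in this assay, and the 4-methylphenyl result extends that flat reading to a fourth group. No measured information bears on this result, so the flat reading stands without any explanation.

Still open, as far as these compounds go, is whether a group of a different kind on this nitrogen, such as cyclohexyl or a phenyl carrying a carboxylic acid or a dimethylamino group, would give a step beyond the scatter. The shared core stays constant throughout, so the compounds shown say nothing about changes there.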